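This account rests on a few compounds, and the source may have more. Where it says the series, first, only, none or still open, it means among the compounds named here.

Compound 1 `CN1CCN(c2nc(-c3ccc(Cl)c(Cl)c3)nc3[nH]cnc23)CC1` in an assay on cells for displacement of a labelled ligand from adenosine receptor A3 (Homo sapiens), read by scintillation counting and radioligand binding, with a stated time of 180 min (a higher number here means a weaker inhibitor, a lower number a stronger inhibitor), gives 39.8 nM. Compound 2 `Clc1ccc(-c2nc(N3CCCCC3)c3nc[nH]c3n2)cc1Cl` gives 79.4 nM. Compound 3 `CN1CCN(c2nc(-c3cccc(O)c3)nc3[nH]cnc23)CC1` gives 501 nM.

Among these three, compound 2 holds the second highest number. Its nearest neighbour is compound 1, and the step of a 2.0-fold higher number from compound 1 to compound 2 (0.30 log units; within the scatter) lies within the scatter, so the two cannot be placed in order. Compound 3 shows a clearly higher number than compound 2, which marks compound 3 as the weaker inhibitor of that pair.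

Compound 4 `Clc1cccc(-c2nc(N3CCCCC3)c3nc[nH]c3n2)c1` differs from compound 2 by hydrogen in place of chloro on an aromatic carbon. For the measured compounds named here, the only measured step that touches this part of the molecule is a 13-fold higher number from compound 1 to compound 3 (1.10 log units; beyond the scatter), where 3-hydroxyphenyl replaces 3,4-dichlorophenyl; that step is large. The change to compound 4 removes just one chloro and adds nothing, so a smaller loss than that step is expected, though likely beyond the scatter: a 2.5-fold higher number from compound 2 to compound 4 (0.40 log units; beyond the scatter). Compound 4 is therefore estimated at 200 nM, with a range from 80 nM to 600 nM.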

Compound 4, inhibition constant: 39.8 nM
For compound 4 the middle estimate is 5.0-fold (0.70 log units) above the measured one, and the stated range ends above it.
By their numbers in this assay, from the lowest: compounds 1, 4 and 2 (each within the scatter of the next); then compound 3.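

Taking away the chloro that sits ortho to a chloro group and para to a large group gives a 2.0-fold lower number from compound 2 to compound 4 (0.30 log units; within the scatter) in this assay, so this one atom makes no readable difference here. The large step of a 13-fold higher number from compound 1 to compound 3 (1.10 log units; beyond the scatter), where 3-hydroxyphenyl replaces 3,4-dichlorophenyl, changes more than this one chloro. With piperidin-1-yl on the shared core, taking away this chloro alone gives no readable change. Nothing measured here explains why this chloro can go without a readable change.

Still open, on these data alone, is whether the remaining chloro matters on its own, which a plain phenyl group would test. Also open, as far as these compounds go, is how a different group at this position, such as methoxy or a carboxylic acid, would compare with hydrogen and chloro.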